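The compounds below may be only part of what the source reports. "The series", "measured", "known", "first", "only" and "open" are said of these compounds alone.

Compound 1, `COc1ccccc1OCC1SCCN1C(=O)C[S+](C)[O-]`, and compound 2, `O=C(O)CC(=O)N1CCSC1COc1ccccc1O`, are built on the same core and differ only in the chain hanging from the amide carbonyl. In a functional assay on the whole organism for inhibition, with Cavia porcellus as the target (on this read-out higher numbers stand for an effect only at larger amounts of compound and lower numbers for an effect already at smaller amounts), compound 1 gives 25 mg/kg. In this assay compound 2 gives 25 mg/kg, so the two compounds stand level at the digits shown, within the usual scatter of this kind of measurement, and compound 1 has no closer neighbour than compound 2.

Compound 3, `COc1ccccc1OCC1SCCN1C(=O)CC(=O)N1CCN(C)CC1`, keeps that core and changes the chain once more: a group of 9 heavy atoms (6 carbon, 2 nitrogen, 1 oxygen; one six-membered non-aromatic ring with 2 hetero atoms) in place of a group of 3 heavy atoms (1 carbon, 1 oxygen, 1 sulfur; no ring), on a saturated chain carbon bound to a carbonyl carbon. Among the measured compounds shown here, no pair of measured compounds shows what a change of this kind does here, so there is no measured step to lean on. The expectation for compound 3 is therefore a step of no change at the digits printed from compound 1 to compound 3 (within the scatter), that is, no change beyond the scatter. Compound 3 is estimated at 25 mg/kg, with a range from 8 mg/kg to 80 mg/kg.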

Compound 3, dose for half-maximal effect: 27 mg/kg
The estimate for compound 3 lay 1.1-fold (0.03 log units) below the measured number, within the range that was stated.
By their numbers in this assay, from the lowest: compounds 1, 2 and 3 (each within the scatter of the next).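

In this assay, placing (4-methylpiperazin-1-yl)carbonyl on a saturated chain carbon bound to a carbonyl carbon, where compound 1 carries a group of 3 heavy atoms and no ring, gives a 1.1-fold higher number from compound 1 to compound 3 (0.03 log units; within the scatter), which lies within the scatter. This read-out therefore does not separate the small open group from a much larger group holding a six-membered non-aromatic ring, so a group of this size is compatible with an effect at this place. Nothing at hand bears on why the two compounds stand level.

Still open, on these data alone, is whether a phenyl ring or a longer unbranched carbon chain at this place would also stay within the scatter. As far as these compounds go, it is equally open whether any group here can move the number beyond the scatter, in either direction.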